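A few compounds are considered here, and "the series" means these few. Any claim that something is new, unique, unknown or untested is made for them only; others in the source may bear on it.

Measured compounds:
- compound 1, `CC1(C)Cc2c(OCc3ccccc3)ccc(C(=O)/C=C/c3cn(-c4ccccc4)nc3-c3cccc([N+](=O)[O-])c3)c2O1`, in a functional assay on PC-3 cells (Homo sapiens) for antiproliferative activity, read by MTT assay, with a stated time of 48 h (on this read-out higher numbers stand for weaker inhibition and lower numbers for stronger inhibition), compound 1 gives 5900 nM
- compound 2, `COc1ccc(/C=C/C(=O)c2ccc(OCc3ccccc3)c3c2OC(C)(C)C3)cc1`, in this assay compound 2 gives 13500 nM

Compound 1 holds the lower of the two numbers in this assay; the gap to compound 2 lies beyond the usual scatter of repeated runs, so compound 1 is the stronger inhibitor of the pair on this read-out. Among the compounds with values here, no single-change step between measured compounds is available, so nothing yet tells how a change on the five-membered aromatic ring with 2 nitrogen moves the number.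

The next compound, compound 3, `CC1(C)Cc2c(OCc3ccccc3)ccc(C(=O)/C=C/c3cn(-c4ccccc4)nc3-c3ccc(Cl)cc3)c2O1`, differs from compound 1 in one place: 4-chlorophenyl in place of 3-nitrophenyl on an aromatic carbon. The change keeps the rest of the shared core untouched. With no measured step of this kind in hand, the expectation for the step of a 1.2-fold lower number from compound 1 to compound 3 (0.07 log units; within the scatter) in this assay is a small one, not clearly beyond the scatter, in either direction. Compound 3 is expected to give about 5000 nM in this assay, with a range from 1500 nM to 15000 nM.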

Compound 3, half-maximal inhibitory concentration: 8400 nM
Estimate against measurement, compound 3: 1.7-fold (0.23 log units) below, within the range that was stated.
By their numbers in this assay, from the lowest: compounds 1, 3 and 2 (each within the scatter of the next, the first and the last beyond it).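

In this assay, within the data shown here, 4-chlorophenyl in place of 3-nitrophenyl on this aromatic carbon gives a 1.4-fold higher number from compound 1 to compound 3 (0.15 log units; within the scatter) and so provides the first reading at this position: on this read-out, the pair cannot be told apart. The nitro group is therefore not required to keep the number within the scatter of compound 1, and the position accepts a chlorine-bearing phenyl group with no hydrogen-bond acceptors in place of a phenyl group that has them. No measurement is at hand that would explain why this exchange leaves the number within the scatter.

Because 3-nitrophenyl and 4-chlorophenyl differ both in the substituent and in where it sits on the phenyl ring, this single step cannot separate those two changes. Also open is how far the tolerance extends, as the compounds shown give no reading for an unsubstituted phenyl group, or for a phenyl ring carrying an amine or a carboxylic acid, at this position.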